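Adding a Carbamoylmethyl Side Chain to Compound 2

A few compounds are considered here, and "the series" means these few. Any claim that something is new, unique, unknown or untested is made for them only; others in the source may bear on it.

Of the compounds shown here, three have been measured in a functional assay on the whole organism (Tail, strain ICR) with Mus musculus as the target, in the tail flick test, with a stated time of 120 min, at a dose of 25 umol/kg by the oral route; a higher number here means a stronger effect of the compound at the dose given, a lower number a weaker effect. Compound 1 `C[C@H](NC(=O)CN(c1nc(Cl)nc2[nH]cnc12)C1CC1)C(=O)OCc1ccccc1` gives 36.1%, compound 2 `O=C(CN(c1ncnc2c1ncn2C1CCCCO1)C1CC1)NCC(=O)OCc1ccccc1` gives 17.2%, and compound 3 `N=C(N)NCCC[C@H](NC(=O)CN(c1nc(Cl)nc2[nH]cnc12)C1CC1)C(=O)OCc1ccccc1` gives 10.2%. Compound 2 stands second of the three: its nearest neighbour is compound 3, within the scatter, while compound 1 lies beyond the scatter above it.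

Compound 4 `NC(=O)C[C@H](NC(=O)CN(c1ncnc2c1ncn2C1CCCCO1)C1CC1)C(=O)OCc1ccccc1` differs from compound 2 by carbamoylmethyl in place of hydrogen on a saturated chain carbon bound to an amide-type nitrogen and a carbonyl carbon. Going by the values given here, the one measured step that bears on this is a number 25.9 percentage points lower from compound 1 to compound 3 (beyond the scatter), where a side chain was likewise placed on the saturated chain carbon of the glycine-like spacer; that step was modest but clearly beyond the scatter, and its direction was downward. Compound 2 carries a different core and a lower starting value than compound 1, so the room for a fall is smaller. Compound 4 is therefore expected to show a step of a number 9.2 percentage points lower from compound 2 to compound 4 (within the scatter) in this assay, downward, with the estimate for compound 4 placed at 8%, ranging from 0% to 24%.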

Compound 4, a percentage reported as activity, at one dose (the size of the read-out at that dose, not a potency): 29.2%
Compound 4: middle estimate off by 21.2 percentage points, on the low side; the measured number lies above the stated range.
By their numbers in this assay, from the lowest: compounds 3 and 2 (each within the scatter of the next); then compounds 4 and 1 (each within the scatter of the next).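

In this assay, carbamoylmethyl in place of hydrogen on this saturated chain carbon gives a number 12 percentage points higher from compound 2 to compound 4 (beyond the scatter), so a side chain at this place does not have to lower the read-out. The earlier step of a number 25.9 percentage points lower from compound 1 to compound 3 (beyond the scatter) ran the other way, with a different group on a different core, which means the compounds shown support no single trend for substitution at this carbon. Nothing available accounts for the rise seen with carbamoylmethyl.

As far as these compounds go, it remains open whether carbamoylmethyl would have the same effect on the core of compound 1, where only the larger nitrogen-rich chain of compound 3 can be read. From the compounds shown here alone, it is also open how a carboxylic acid or a longer chain ending in the same primary amide would behave at this carbon on the core of compound 2.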